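Swapping 2,5-difluorophenyl for pyridin-4-yl

A few compounds are considered here, and "the series" means these few. Any claim that something is new, unique, unknown or untested is made for them only; others in the source may bear on it.

Three compounds have been measured in a functional assay on HCT-116 cells (Homo sapiens) for cytotoxicity, read by CellTiter-Glo, with a stated time of 5 days (a lower number here means a stronger inhibitor, a higher number a weaker inhibitor), so far:
compound 1 `COc1ccc(-n2nc(Nc3cc(C)[nH]n3)c3ccccc3c2=O)cc1` gives 700 nM
compound 2 `Cc1cc(Nc2nn(-c3ccc(F)cc3)c(=O)c3ccccc23)n[nH]1` gives 800 nM
compound 3 `Cc1cc(Nc2nn(Cc3cc(F)ccc3F)c(=O)c3ccccc23)n[nH]1` gives 570 nM

Compound 3 gives 570 nM and cannot be separated from the other two, with a 1.2-fold lower number from compound 1 to compound 3 (0.09 log units; within the scatter) and a 1.4-fold lower number from compound 2 to compound 3 (0.15 log units; within the scatter) as its measured steps. Compound 4 `Cc1cc(Nc2nn(Cc3ccncc3)c(=O)c3ccccc23)n[nH]1` carries pyridin-4-yl in place of 2,5-difluorophenyl on a saturated chain carbon bound to an aromatic nitrogen, and pyridin-4-yl in place of 2,5-difluorophenyl on a saturated chain carbon bound to an aromatic nitrogen sums up that change. The two steps of compound 3 bear most closely on it, since both exchange the group on the aromatic nitrogen, and both stayed small. So did a 1.1-fold higher number from compound 1 to compound 2 (0.06 log units; within the scatter) for fluoro in place of methoxy. None of these compounds has a hetero atom in the aromatic ring at this place, so that feature remains untested. In this assay no change beyond the scatter is therefore expected, with a slight lean towards a higher number and a 1.4-fold higher number from compound 3 to compound 4 (0.15 log units; within the scatter) as the estimated step. Compound 4 is estimated at 800 nM within an expected range from 280 nM to 2400 nM for repeat measurements.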

Compound 4, half-maximal inhibitory concentration: 20200 nM
For compound 4 the middle estimate is 25-fold (1.40 log units) below the measured one; measured number outside the range, above it.
By their numbers in this assay, from the lowest: compounds 3, 1 and 2 (each within the scatter of the next); then compound 4.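

In this assay, going by these compounds alone, the group on the aromatic nitrogen proves far from indifferent: pyridin-4-yl in place of 2,5-difluorophenyl gives a 35-fold higher number from compound 3 to compound 4 (1.55 log units; beyond the scatter) while every step among the earlier compounds stayed within the scatter. The same large rise appears against the directly ring-bound groups, with a 25-fold higher number from compound 2 to compound 4 (1.40 log units; beyond the scatter) and a 29-fold higher number from compound 1 to compound 4 (1.46 log units; beyond the scatter) as the readings, so compound 4 stands apart from all three earlier compounds, and it is the only one of them with a hetero atom in this aromatic ring. No measurement shown here gives a reason for this rise.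

As far as these compounds go, compound 4 gains the ring nitrogen and loses both fluorines in a single change, so the share of each remains open. A plain benzyl group, or (pyridin-3-yl)methyl, would separate these contributions and test whether the placing of the ring nitrogen matters.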